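The compounds below may be only part of what the source reports. "The series", "measured", "known", "first", "only" and "open" are said of these compounds alone.

Measured so far:
compound 1, `Cc1ccc(-c2nn(-c3ccc(F)cc3F)cc2CNCCN2CCN(C)CC2)cc1`: > 20000 nM
compound 2, `CSc1ccc(-n2cc(CNCCN3CCN(C)CC3)c(-c3ccccc3C)n2)cc1`: 17000 nM

Both compounds were tested in an ADME assay on Huh-7 cells (Homo sapiens) for cytotoxicity; a lower number here means that less compound is tolerated, a higher number that more compound is tolerated. Compound 1 gives only a limit in this assay, namely > 20000 nM, so its true value is not known as a number. Compound 2 in this assay gives 17000 nM. Compound 1 stands at the edge of the numbers shown, because the limit of > 20000 nM in this assay, at which 1 of the 2 values shown sits, marks where it sits. Compound 3 is `Cc1cccc(-c2nn(-c3ccc(F)cc3F)cc2CNCCN2CCN(C)CC2)c1`; it differs from compound 1 by 3-methylphenyl in place of 4-methylphenyl on an aromatic carbon. Among the compounds with values here, no step between two measured compounds shows how such a change moves this assay. Since the group that leaves and the group that enters differ so little, no step beyond the scatter is expected in either direction. For compound 3 the estimated value in this assay is 20000 nM, with a range from 10000 nM to 40000 nM. The expected step from compound 1 to compound 3 that this estimate means is a number no higher from compound 1 to compound 3 (the limit leaves the size open), within the scatter.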

Compound 3, half-maximal cytotoxic concentration: > 20000 nM
Compound 3 gave a limit, no number; the forecaster's own chance of this, stated with the estimate: 55%; the middle value lies on the limit itself.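

In this assay, within the data shown here, compound 1 and compound 3 both give only a limit and not a number, so no step between them can be read. Going by these compounds, whether 3-methylphenyl in place of 4-methylphenyl moves the result in this assay at all stays open, as does how far each true value lies beyond the limit.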